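Swapping One Aryl Group on a Shared Fused Core

The source may hold more compounds than are shown below. What is called first, only, known or untested is meant among the compounds shown, and "the series" means these compounds.

Compound 1 `Cc1nc2c3ccccc3ccc2c2nc3c(ccc4ccccc43)c(-c3ccccc3S)c12`: 49.6 ug/mL
Compound 2 `Cc1ccc(-c2c3ccc4ccccc4c3nc3c2c(C)nc2c4ccccc4ccc32)cc1`: 68.7 ug/mL
Compound 3 `Cc1nc2c3ccccc3ccc2c2nc3c(ccc4ccccc43)c(-c3cccc4ccccc34)c12`: 64.3 ug/mL

In a functional assay, read by spectrophotometry, with a stated time of 15 min (on this read-out higher numbers stand for weaker inhibition and lower numbers for stronger inhibition), compound 2 gives the highest of the three numbers, yet the step of a 1.4-fold higher number from compound 1 to compound 2 (0.14 log units; within the scatter) and the step of a 1.1-fold lower number from compound 2 to compound 3 (0.03 log units; within the scatter) both stay within the scatter, as does a 1.3-fold higher number from compound 1 to compound 3 (0.11 log units; within the scatter). So far, exchanging the ring group on this aromatic carbon has not moved the number beyond what repeated measurement would show. Compound 4 `Cc1nc2c3ccccc3ccc2c2nc3c(ccc4ccccc43)c(-c3cccnc3)c12` has not yet been measured; it differs from compound 2 by pyridin-3-yl in place of 4-methylphenyl on an aromatic carbon. The three measured steps all bear on this change, each replacing one ring group at the same position, and all were within the scatter. Compound 4 is therefore expected to sit close to compound 2. The expected step of a 1.1-fold lower number from compound 2 to compound 4 (0.06 log units; within the scatter) stays within the scatter. Compound 4 is estimated at 60 ug/mL, likely between 30 ug/mL and 120 ug/mL.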

Compound 4, half-maximal inhibitory concentration: 63.6 ug/mL
For compound 4 the middle estimate is 1.1-fold (0.03 log units) below the measured one, within the range that was stated.
By their numbers in this assay, from the lowest: compounds 1, 4, 3 and 2 (each within the scatter of the next).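

In this assay, pyridin-3-yl puts a ring nitrogen and a hydrogen-bond acceptor on this aromatic carbon where 4-methylphenyl has neither, yet a 1.1-fold lower number from compound 2 to compound 4 (0.03 log units; within the scatter) stays within the scatter. The same holds for a 1.0-fold lower number from compound 3 to compound 4 (0.00 log units; within the scatter) and for a 1.3-fold higher number from compound 1 to compound 4 (0.11 log units; within the scatter) as well, so swapping in this nitrogen-containing ring leaves the number indistinguishable from those of the carbon-only rings. No measurement shown here offers an explanation for this.

All four groups at this position are six-membered aromatic rings or contain them. Going by these compounds, whether an amine, a carboxylic acid or a longer alkyl chain here would move the number beyond the scatter remains open.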